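Methyl in Place of Methoxy: Expected Shift in Lipophilicity

A few compounds are considered here, and "the series" means these few. Any claim that something is new, unique, unknown or untested is made for them only; others in the source may bear on it.

Compounds measured so far:
compound 1 `CN(Cc1ccc2nccn2c1)c1nnc(-c2ccccc2)o1` gives 2.4
compound 2 `CN(Cc1ccc2nccn2c1)c1nnc(-c2ccc(-c3ccccc3F)cc2)o1` gives 4.4
compound 3 `COc1ccccc1-c1ccc(-c2nnc(N(C)Cc3ccc4nccn4c3)o2)cc1` gives 4.1

In a physicochemical assay for lipophilicity, at pH 7.4 (on this read-out lower numbers stand for lower lipophilicity and higher numbers for higher lipophilicity), compound 3 stands second highest of the three numbers. Its nearest neighbour is compound 2, with a number 0.30 log units lower from compound 2 to compound 3 (within the scatter); furthest away is compound 1, with a number 1.70 log units higher from compound 1 to compound 3 (beyond the scatter).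

Compound 4 `Cc1ccccc1-c1ccc(-c2nnc(N(C)Cc3ccc4nccn4c3)o2)cc1` differs from compound 3 by methyl in place of methoxy on an aromatic carbon. The step that bears most directly on it is a number 0.30 log units lower from compound 2 to compound 3 (within the scatter), an exchange at the same place that stayed within the scatter, whereas a number 2.00 log units higher from compound 1 to compound 2 (beyond the scatter) shows what a whole attached ring does. A small upward step is therefore expected for compound 4, a number 0.30 log units higher from compound 3 to compound 4 (within the scatter). Compound 4 is estimated at 4.4, between 4 and 4.8.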

Compound 4, distribution coefficient: 4.7
For compound 4 the middle estimate is 0.30 log units below the measured one; low and high end bracket the measured number.
By their numbers in this assay, from the lowest: compound 1; then compounds 3, 2 and 4 (each within the scatter of the next, the first and the last beyond it).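

In this assay an exchange of the group at this place now leaves the scatter, with a number 0.60 log units higher from compound 3 to compound 4 (beyond the scatter) for methyl in place of methoxy, while a number 0.30 log units higher from compound 2 to compound 4 (within the scatter) keeps methyl and fluoro level. The attached ring as a whole still accounts for most of the shift, with a number 2.30 log units higher from compound 1 to compound 4 (beyond the scatter) for 2-methylphenyl in place of hydrogen. Nothing at hand explains why methyl and methoxy differ here. From the compounds shown here alone, how an amine or a carboxylic acid at this place would read remains open, as does whether the methyl-for-methoxy step would hold elsewhere on the ring.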